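The source may report more compounds than this note shows. Statements on the series, on what has been measured and on what is new or still open speak of the compounds shown alone.

Three related compounds have entries in an ADME assay on Huh-7 cells (Homo sapiens) for cytotoxicity, with a stated time of 72 h; on this read-out higher numbers stand for lower toxicity in this test and lower numbers for higher toxicity in this test. Compound 1 `COCN(c1ccc2c(c1)S(=O)(=O)N=C(c1c(O)c(-c3cccs3)nn(CCC(C)C)c1=O)N2)S(C)(=O)=O` gives > 1000 nM, which is a limit of the assay and not a number. Compound 2 `CC(C)CCn1nc(-c2cccs2)c(O)c(C2=NS(=O)(=O)c3cc(S(=O)(=O)N(C)C)ccc3N2)c1=O` has the entry "not determined" (no result reported). Compound 3 `CCC(C)CCn1nc(-c2cccs2)c(O)c(C2=NS(=O)(=O)c3cc(NS(C)(=O)=O)ccc3N2)c1=O` gives > 1000 nM, again a limit and not a number. Compound 3 therefore stands at the same limit as compound 1, and none of the three has yet yielded an exact number in this assay.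

Compound 4 `CCC(C)n1nc(-c2cccs2)c(O)c(C2=NS(=O)(=O)c3cc(NS(C)(=O)=O)ccc3N2)c1=O` keeps the shared core and changes one chain: sec-butyl in place of 3-methylpentyl on an aromatic nitrogen. In words, sec-butyl replaces 3-methylpentyl on an aromatic nitrogen. Going by the values given here, no pair of measured compounds shows what a change at this place does, so the expectation rests on the limit reached by compound 3 at > 1000 nM. No step beyond the usual scatter is expected in this assay, and compound 4 will most likely be reported at a limit too. The expected step that the limit leaves unreadable from compound 3 to compound 4 is an estimate only. For compound 4 the estimated value is 1500 nM, with an expected range from 700 nM to 10000 nM.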

Compound 4, half-maximal cytotoxic concentration: > 33000 nM
Compound 4 gave a limit, no number (the forecaster's own chance of this, stated with the estimate: 85%); middle value at least 22-fold (1.34 log units) from the limit.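

Going by these compounds alone, compound 3 and compound 4 both give limits and not numbers in this assay, so no step between them can be read. The compounds shown leave open what exact toxicity each has in this test, and what sec-butyl in place of 3-methylpentyl actually changes.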